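Methyl to Trifluoromethyl on the Sulfur-Linked Benzyl Arm

The compounds below may be only part of what the source reports. "The series", "measured", "known", "first", "only" and "open" are said of these compounds alone.

Of the compounds shown here, three that share one core have been measured in an ADME assay on HaCaT cells (Homo sapiens) for cytotoxicity, read by MTT assay, with a stated time of 72 h; on this read-out lower numbers stand for stronger inhibition and higher numbers for weaker inhibition. Compound 1 `Cc1cc(S(=O)(=O)/N=C(\N)n2nccc2-c2ccccc2)c(SCc2ccccc2C)cc1Cl` gives 18000 nM. Compound 2 `Cc1cc(-c2ccccc2)n(/C(N)=N/S(=O)(=O)c2cc(C)c(Cl)cc2SCc2cccc(C(F)(F)F)c2)n1` gives 40000 nM, and compound 3 `Cc1cc(-c2ccccc2)n(/C(N)=N/S(=O)(=O)c2cc(C)c(Cl)cc2SCc2ccc(Cl)cc2)n1` gives 11000 nM. Compound 1 therefore stands second highest of the three: its gap to compound 3 lies within the scatter, while its gap to compound 2 lies beyond it.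

Compound 4 `Cc1cc(S(=O)(=O)/N=C(\N)n2nccc2-c2ccccc2)c(SCc2ccccc2C(F)(F)F)cc1Cl` differs from compound 1 by trifluoromethyl in place of methyl on an aromatic carbon. The single measured step among these compounds, a 3.6-fold lower number from compound 2 to compound 3 (0.56 log units; beyond the scatter), exchanged one aromatic group for another on a saturated chain carbon bound to a sulfur, and there the compound carrying a trifluoromethyl group, compound 2, showed the higher number. That step does not repeat the present change, so it gives only a loose hint. A modest rise in the number, possibly no more than the scatter, is expected for compound 4, a 1.4-fold higher number from compound 1 to compound 4 (0.14 log units; within the scatter). The estimate for compound 4 in this assay is 25000 nM, with a range from 10000 nM to 60000 nM.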

Compound 4, half-maximal inhibitory concentration: 20000 nM
The estimate for compound 4 lay 1.3-fold (0.10 log units) above the measured number; low and high end bracket the measured number.
By their numbers in this assay, from the lowest: compounds 3, 1, 4 and 2 (each within the scatter of the next, the first and the last beyond it).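

In this assay, the exchange of methyl for trifluoromethyl gives a 1.1-fold higher number from compound 1 to compound 4 (0.05 log units; within the scatter), so this direct comparison does not separate compound 1 from compound 4. Among these compounds, it is the first measured change at this place, an aromatic carbon ortho to a large group, and it shows that going from a group of 1 heavy atom to one of 4 heavy atoms leaves no readable difference in this cell read-out. No measurement at hand offers an explanation for this result.

From the compounds shown here alone, whether an amine or a carboxylic acid on the same aromatic carbon would give a number beyond the scatter remains open. Also open, going by these compounds, is whether the same exchange of methyl for trifluoromethyl would read the same way with a different group elsewhere on the shared core.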